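Trading a ring amine for an open-chain amine

The compounds below may be only part of what the source reports. "The series", "measured", "known", "first", "only" and "open" are said of these compounds alone.

Compound 1 `COc1cc(OC)c2c(=O)cc(-c3ccc(OC4CCN(C)CC4)cc3)oc2c1` gives 49% in a functional assay (Homo sapiens) for antiproliferative activity, read by resazurin assay, with a stated time of 48 h, tested at 10 uM; a higher number here means a stronger effect of the compound at the concentration tested, a lower number a weaker effect.
Compound 2 `COc1cc(OC)c2c(=O)cc(-c3ccc(OCCN4CCCC4=O)cc3)oc2c1` gives 14% in this assay.
Compound 3 `COc1cc(OC)c2c(=O)cc(-c3ccc(OC4CCNCC4)cc3)oc2c1` gives 21% in this assay.

Compound 3 stands second highest of these three numbers. Its gap to compound 2 is small, a number 7 percentage points higher from compound 2 to compound 3 (within the scatter), so the two cannot be told apart here. Its gap to compound 1 is real: a number 28 percentage points lower from compound 1 to compound 3 (beyond the scatter), and that step only removed a methyl from the amine nitrogen in the ring.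

Compound 4 `COc1cc(OC)c2c(=O)cc(-c3ccc(OCCCN)cc3)oc2c1` is the next case. Its difference from compound 3 is 3-aminopropyl in place of piperidin-4-yl on an oxygen on an aromatic ring. Within the data shown here, two measured steps bear on this. The step of a number 28 percentage points lower from compound 1 to compound 3 (beyond the scatter) shows that a change at the amine nitrogen in this part of the molecule can move the number noticeably. The step of a number 7 percentage points higher from compound 2 to compound 3 (within the scatter) shows that swapping a ring for an open chain at the same oxygen, with a nitrogen kept in the group, stayed within the scatter. Compound 4 keeps a free amine as donor and acceptor but loses the ring; nothing measured tests exactly that. The expected step of a number 3 percentage points lower from compound 3 to compound 4 (within the scatter) is therefore small, likely within the scatter, with a slight lean downward. Compound 4 is estimated at 18%, between 5% and 38%.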

Compound 4, a percentage reported as inhibition, at one concentration (the size of the read-out at that concentration, not a potency): 39%
The estimate for compound 4 lay 21 percentage points below the measured number; the whole stated range lies below it.
By their numbers in this assay, from the lowest: compounds 2 and 3 (each within the scatter of the next); then compounds 4 and 1 (each within the scatter of the next).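

In this assay, at this oxygen on an aromatic ring, the ring of piperidin-4-yl and the open chain of 3-aminopropyl are not interchangeable, even though both groups count one hydrogen-bond donor and one acceptor: a number 18 percentage points higher from compound 3 to compound 4 (beyond the scatter). An open chain does not by itself keep the number low, since what sits at its end also counts: a number 25 percentage points higher from compound 2 to compound 4 (beyond the scatter), with aminomethyl in place of 2-oxopyrrolidin-1-yl. The other step, a number 10 percentage points lower from compound 1 to compound 4 (within the scatter), puts 3-aminopropyl level with 1-methylpiperidin-4-yl, so among these compounds the low number of compound 3 does not follow simply from the presence of an amine nitrogen with no methyl on it, as compound 4 carries such a nitrogen too.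

Nothing available here explains why these groups differ. Still open, going by these compounds, is whether a longer chain such as 4-aminobutyl, or 3-(dimethylamino)propyl with two methyl groups on the chain nitrogen, would hold the number near that of compound 4 or move it.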